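The compounds below may be only part of what the source reports. "The series", "measured", "known", "first", "only" and "open" are said of these compounds alone.

Measured so far, in an ADME assay for pharmacokinetics, read by HPLC, in phosphate buffer, at 37 degrees C, at pH 8; on this read-out lower numbers stand for a shorter-lived compound and higher numbers for a longer-lived compound:

compound 1, `CCCOC(=O)OCC(CO)CCn1cnc2cnc(N)nc21`: 96 h
compound 2, `CCCCCOC(=O)OCC(CO)CCn1cnc2cnc(N)nc21`: 120 h
compound 3, `CCCCOC(=O)OCC(CO)CCn1cnc2cnc(N)nc21`: 120 h

All three share one core and differ only in the alkyl chain on the carbonate. Among them the spread is small: a 1.3-fold lower number from compound 2 to compound 1 (0.10 log units; within the scatter), and a 1.3-fold higher number from compound 1 to compound 3 (0.10 log units; within the scatter); compound 2 and compound 3 sit level, no change at the digits printed from compound 2 to compound 3 (within the scatter). Among the compounds with values here, no compound can be called longer- or shorter-lived than another on these numbers.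

The unmeasured compound 4, `CCOC(=O)OCC(CO)CCn1cnc2cnc(N)nc21`, is to be measured in this assay. It is made from compound 3 by the change (hydrogen in place of ethyl on a saturated chain carbon, two bonds along the chain from an oxygen next to a carbonyl group). The same kind of change has been measured once already, from compound 2 to compound 1: hydrogen in place of ethyl on a saturated chain carbon, three bonds along the chain from an oxygen next to a carbonyl group. The two places are not the same word for word: in the measured pair the hydrogen enters three bonds along the chain from an oxygen next to a carbonyl group, in the new pair two bonds along the chain from an oxygen next to a carbonyl group, so the chain is cut one carbon shorter still. The two starting points, compound 2 and compound 3, differ by hydrogen in place of methyl on a saturated chain carbon, four bonds along the chain from an oxygen next to a carbonyl group.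

Within the data shown here, the one measured step of this kind was small, a 1.3-fold lower number from compound 2 to compound 1 (0.10 log units; within the scatter), and all three chain lengths so far lie within the scatter of one another. Among the measured compounds shown here, a step of about the same size is expected here, a 1.3-fold lower number from compound 3 to compound 4 (0.10 log units; within the scatter), resting on that single step from compound 2 to compound 1; with only one precedent the range is kept wide. Compound 4 is estimated at 96 h, between 60 h and 150 h.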

Compound 4, half-life: 72 h
Beside the measured number, compound 4's estimate is 1.3-fold (0.12 log units) above it, within the range that was stated.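

Removing ethyl gives steps that agree on the two starting compounds, so in this series the change carries from one to the other without a detectable difference: the same change on two cores in this assay, a 1.3-fold lower number (0.10 log units; within the scatter) from compound 2 to compound 1 and a 1.7-fold lower number (0.22 log units; within the scatter) from compound 3 to compound 4, 1.3-fold (0.12 log units) apart, within the scatter of two such steps

Removing methyl gives the same picture: the same change on two cores in this assay, no change at the digits printed (within the scatter) from compound 2 to compound 3 and a 1.3-fold lower number (0.12 log units; within the scatter) from compound 1 to compound 4, 1.3-fold (0.12 log units) apart, within the scatter of two such steps

In this assay, the three new steps, a 1.7-fold lower number from compound 3 to compound 4 (0.22 log units; within the scatter), a 1.7-fold lower number from compound 2 to compound 4 (0.22 log units; within the scatter) and a 1.3-fold lower number from compound 1 to compound 4 (0.12 log units; within the scatter), all stay inside the scatter, so this agreement is between small steps and is only a weak test of transfer: it does not show that chain length sets the half-life, and it gives no trend across the ethyl, propyl, butyl and pentyl carbonates.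

The compounds shown cover only straight alkyl chains on a carbonate of the shared core, so a longer chain such as octyl, a branched chain such as isopropyl, or a chain carrying an amine or a carboxylic acid remains open. Also open, on these data alone, is whether a real chain-length effect would emerge with an ester or a carbamate in place of the carbonate.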